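Swapping the Ether Chain for a 3-Chlorophenyl Group

The source may hold more compounds than are shown below. What is called first, only, known or untested is meant among the compounds shown, and "the series" means these compounds.

Compound 1 `CCOC(=O)c1c(C)nc(-c2ccccc2C#N)n1OC` gives 14900 nM in a functional assay on a cell-free system (plasma, Oryctolagus cuniculus) for inhibition, with stated times of 5 min, 1 min and 6 min; a lower number here means a stronger inhibitor, a higher number a weaker inhibitor.
Compound 2 `CCOC(=O)c1c(C)nc(-c2cccc(C#N)c2)n1C(C)C` gives 9260 nM in this assay.
Compound 3 `CCOCCOn1c(-c2cccc(C#N)c2)nc(C)c1C(=O)OCC` gives 6250 nM in this assay.

Compound 3 holds the lowest of the three numbers; compound 2 is its nearest neighbour, within the scatter, while compound 1 lies beyond it. Compound 4 `CCOC(=O)c1c(C)nc(-c2cccc(C#N)c2)n1OCc1cccc(Cl)c1` differs from compound 3 by 3-chlorophenyl in place of ethoxymethyl on a saturated chain carbon bound to an oxygen on an aromatic ring. Among the compounds with values here, the only measured step touching this part of the molecule is a 1.5-fold lower number from compound 2 to compound 3 (0.17 log units; within the scatter), which stayed within the scatter, and no measured pair tests an aromatic ring in place of the chain. The step from compound 3 is therefore expected to be a 1.6-fold lower number from compound 3 to compound 4 (0.19 log units; within the scatter), a small shift if any. Compound 4 is expected to give 4000 nM in this assay, between 1500 nM and 12000 nM.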

Compound 4, half-maximal inhibitory concentration: 19400 nM
Compound 4: the middle estimate sits 4.9-fold (0.69 log units) below what was measured, and the stated range ends below it.
By their numbers in this assay, from the lowest: compounds 3, 2, 1 and 4 (each within the scatter of the next, the first and the last beyond it).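

In this assay the group on the aromatic nitrogen now makes a difference beyond the scatter: the earlier change (a 1.5-fold lower number from compound 2 to compound 3 (0.17 log units; within the scatter)) did not, whereas 3-chlorophenyl in place of ethoxymethyl does (a 3.1-fold higher number from compound 3 to compound 4 (0.49 log units; beyond the scatter)). The (3-chlorobenzyl)oxy group also separates from isopropyl (a 2.1-fold higher number from compound 2 to compound 4 (0.32 log units; beyond the scatter)). Nothing available explains these steps. The compounds shown leave open whether the aromatic ring or its chlorine carries the change, and how an unsubstituted benzyl group or a chain ending in an amine would behave here.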